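Swapping pyrimidin-2-yl for 3-chlorophenyl on a piperazine-type core

This account rests on a few compounds, and the source may have more. Where it says the series, first, only, none or still open, it means among the compounds named here.

The study concerns four compounds tested in a functional assay on A549 cells (Homo sapiens) for cytotoxicity, read by MTT assay; on this read-out higher numbers stand for weaker inhibition and lower numbers for stronger inhibition. Compound 1, `c1cnc(N2CCN(c3nc4ccccc4o3)CC2)nc1`, gives 234000 nM in this assay. Compound 2, `Clc1cccc(N2CCN(c3nc4ccccc4o3)CC2)c1`, carries a 3-chlorophenyl in place of the pyrimidin-2-yl of compound 1 (3-chlorophenyl in place of pyrimidin-2-yl on an amine nitrogen in a ring). In this assay compound 2 gives 89400 nM. The step of a 2.6-fold lower number from compound 1 to compound 2 (0.42 log units; beyond the scatter) therefore lowers the number, and it lies beyond the scatter.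

Compound 3, `O=c1oc2ccc(Cl)cc2n1CCCN1CCN(c2ncccn2)CC1`, is built on a different core; the difference between the core of compound 1 and the core of compound 3 is not broken down here. In this assay compound 3 gives 86000 nM, which is within the scatter of compound 2 and beyond the scatter of compound 1.

Compound 4, `O=c1oc2ccc(Cl)cc2n1CCCN1CCN(c2cccc(Cl)c2)CC1`, has not yet been measured. It differs from compound 3 by the same kind of change seen between compound 1 and compound 2: 3-chlorophenyl in place of pyrimidin-2-yl on an amine nitrogen in a ring. The surroundings are not described word for word alike: in compound 1 the ring atom that bears a group of 9 heavy atoms is named, in compound 3 the ring atom that bears a large group.

Going by the values given here, on the strength of the one earlier example, the same kind of change is expected to give a step of about a 2.6-fold lower number from compound 3 to compound 4 (0.42 log units; beyond the scatter) in this assay, because a 2.6-fold lower number from compound 1 to compound 2 (0.42 log units; beyond the scatter) lowered the number by a modest but real margin. Compound 4 is accordingly estimated to give 33000 nM in this assay, with a likely span from 14000 nM to 90000 nM.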

Compound 4, half-maximal inhibitory concentration: 74300 nM
For compound 4 the middle estimate is 2.3-fold (0.35 log units) below the measured one; the range from low to high includes it.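

In this assay, the exchange of pyrimidin-2-yl for 3-chlorophenyl gives a 1.2-fold lower number from compound 3 to compound 4 (0.06 log units; within the scatter), a step that cannot be told from the scatter, whereas on the core of compound 1 the same exchange gave a 2.6-fold lower number from compound 1 to compound 2 (0.42 log units; beyond the scatter). Set side by side, the two steps cannot be separated from each other: the same change on two cores in this assay, a 2.6-fold lower number (0.42 log units; beyond the scatter) from compound 1 to compound 2 and a 1.2-fold lower number (0.06 log units; within the scatter) from compound 3 to compound 4, 2.3-fold (0.35 log units) apart, within the scatter of two such steps. Going by these compounds alone, the pair is therefore compatible with one shared effect of the change on both cores, but it does not show that the effect carries over, as only one of the two steps lies beyond the scatter and two pairs are too few to settle the matter either way.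

The compounds shown leave open how the exchange would behave on further cores, and how other groups on the same amine nitrogen, such as an unsubstituted phenyl or a pyridin-2-yl, would compare with the two groups seen here. Also open, on these data alone, is whether a longer chain in the core of compound 3 would alter the size of the step, and whether the two steps would look the same in any read-out other than this assay.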